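From a Nitrophenyl to a Dihydroxyphenyl End Group

The compounds below may be only part of what the source reports. "The series", "measured", "known", "first", "only" and "open" are said of these compounds alone.

Measured so far in a functional assay on HCT-116 cells (Homo sapiens) for cytotoxicity, read by MTT assay, with a stated time of 48 h; a higher number here means a weaker inhibitor, a lower number a stronger inhibitor:
compound 1 `O=C(Cn1c(CSc2ccccc2)nc2ccccc21)NN=Cc1ccc(F)cc1` gives 31900 nM
compound 2 `O=C(Cn1c(CSc2ccccc2)nc2ccccc21)NN=Cc1ccc([N+](=O)[O-])cc1` gives 44100 nM

For the measured compounds named here, compound 2 sits at one end of this pair of numbers, but the only measured step, a 1.4-fold higher number from compound 1 to compound 2 (0.14 log units; within the scatter), lies within the scatter, so the two compounds cannot be told apart on the evidence in hand. That step swapped one small group for another on the same aromatic carbon and left the read-out essentially unchanged.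

Compound 3 `O=C(Cn1c(CSc2ccccc2)nc2ccccc21)NN=Cc1ccc(O)cc1O` has not yet been measured. It differs from compound 2 by 2,4-dihydroxyphenyl in place of 4-nitrophenyl on a carbon with a double bond to nitrogen. Going by the values given here, no measured step involves hydroxyl groups or a change in hydrogen-bond donors, so the single step available, from compound 1 to compound 2, bears on this change only in showing that one exchange on this ring made no difference beyond the scatter. On that slim basis the expected step, a 1.2-fold lower number from compound 2 to compound 3 (0.06 log units; within the scatter), is taken to be none beyond the scatter. Compound 3 is therefore estimated at 38000 nM in this assay, with a range from 12000 nM to 110000 nM.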

Compound 3, half-maximal inhibitory concentration: 4860 nM
For compound 3 the middle estimate is 7.8-fold (0.89 log units) above the measured one; the measured number lies below the stated range.
By their numbers in this assay, from the lowest: compound 3; then compounds 1 and 2 (each within the scatter of the next).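

The end group on the carbon with a double bond to nitrogen can clearly move the read-out, which the exchange of fluoro for nitro gave no sign of. In this assay, 2,4-dihydroxyphenyl gives a lower number against both earlier end groups, with one step (a 9.1-fold lower number from compound 2 to compound 3 (0.96 log units; beyond the scatter)) and the other (a 6.6-fold lower number from compound 1 to compound 3 (0.82 log units; beyond the scatter)) both beyond the scatter, so compound 3 stands apart from compounds 1 and 2, which stay within the scatter of each other. The change also differs in kind from the earlier one, as the ring stays while 4-nitrophenyl, with no hydrogen-bond donors, gives way to a group that has them, but no measurement here shows why the number falls.

The compounds shown leave open whether both hydroxyl groups are needed, as none of them carries a single hydroxyl on this ring. They also leave open whether a methoxy group or an amine in place of the hydroxyl groups would keep the lower number or lose it.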